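Estimating compound 4 from three closely spaced values

A few compounds are considered here, and "the series" means these few. Any claim that something is new, unique, unknown or untested is made for them only; others in the source may bear on it.

Compound 1 `CC1CN(C(=O)c2ccc(-c3ccc(NC(=O)Nc4ccc(Cl)c(C(F)(F)F)c4)cc3)cc2)CC(C)O1`: 41900 nM
Compound 2 `CC(NC(=O)/C=C/c1ccc(NC(=O)Nc2ccc(Cl)c(C(F)(F)F)c2)cc1)c1ccccc1`: 21200 nM
Compound 3 `CNC(=O)/C=C/c1ccc(NC(=O)Nc2ccc(Cl)c(C(F)(F)F)c2)cc1`: 21200 nM

In a functional assay on KETR3 cells (Homo sapiens) for inhibition, read by MTT assay, with a stated time of 120 h (on this read-out higher numbers stand for weaker inhibition and lower numbers for stronger inhibition), compound 3 gives 21200 nM. This is level with compound 2 at 21200 nM, and compound 1 at 41900 nM lies within the scatter of both. The next compound to be tested is compound 4 `O=C(CCc1ccc(NC(=O)Nc2ccc(Cl)c(C(F)(F)F)c2)cc1)NC1CCC1`, which differs from compound 3 as follows: 2-(cyclobutylcarbamoyl)ethyl in place of 2-(methylcarbamoyl)ethenyl on an aromatic carbon. In words, 2-(cyclobutylcarbamoyl)ethyl stands in place of 2-(methylcarbamoyl)ethenyl on an aromatic carbon. Among the measured compounds shown here, the only measured step that bears on this shows no change at the digits printed from compound 2 to compound 3 (within the scatter), and it also exchanges the group on the amide-type nitrogen. For the measured compounds named here, no measured step covers the change from ethenyl to ethyl, so that part of the change remains untested. On this evidence, no shift beyond the scatter is expected in this assay. The expected step is a 1.1-fold lower number from compound 3 to compound 4 (0.03 log units; within the scatter). For compound 4 the estimated value is 20000 nM, with an expected range from 9000 nM to 42000 nM.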

Compound 4, half-maximal inhibitory concentration: > 50000 nM
Compound 4 gave a limit, no number; the forecaster's own chance of this, stated with the estimate: 15%; at least 2.5-fold (0.39 log units) between middle value and limit.
By their numbers in this assay, from the lowest: compounds 2, 3 and 1 (each within the scatter of the next). At a limit, above all of these: compound 4.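

In this assay, the exchange on the aromatic carbon para to a large group gives an at least 2.3-fold higher number from compound 3 to compound 4 (0.37 log units; beyond the scatter). Among the compounds shown, this is the first step beyond the scatter; the earlier exchange on the amide-type nitrogen gave no change at the digits printed from compound 2 to compound 3 (within the scatter). Compound 4 gives a limit of the assay, not a number, so the full size of the step stays unknown: the limit of > 50000 nM in this assay, at which 1 of the 4 values shown sits.

The step joins two changes, ethenyl to ethyl in the chain and methyl to cyclobutyl on the amide nitrogen, and the compounds shown cannot tell which of them carries it. As far as these compounds go, it also stays open how a 2-(methylcarbamoyl)ethyl group, a 2-(cyclobutylcarbamoyl)ethenyl group, or a carboxylic acid or an amine at this position would read in this assay.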